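The source may hold more compounds than are shown below. What is called first, only, known or untested is meant among the compounds shown, and "the series" means these compounds.

Three compounds have been measured in an assay on isolated protein for inhibition of Dihydrofolate reductase (Mus musculus); a lower number here means a less potent compound, a higher number a more potent compound, by a factor of ten per unit of this negative logarithm:

Compound 1, `CC1(C)N=C(N)N=C(N)N1c1ccc(OCc2cccc(S(=O)(=O)F)c2)c(Cl)c1`, gives 7.72.
Compound 2, `CC1(C)N=C(N)N=C(N)N1c1ccc(CCCCc2cc(Cl)ccc2S(=O)(=O)F)c(Cl)c1`, gives 7.06.
Compound 3, `CC1(C)N=C(N)N=C(N)N1c1ccc(OCc2ccc(C(=O)Nc3cccc(S(=O)(=O)F)c3)cc2)c(Cl)c1`, gives 7.41.

Compound 3 stands second highest of these three numbers. Compound 1 lies above it by a gap that is beyond the usual scatter of this kind of measurement, and compound 2 lies below it, again beyond the scatter. All three share the same core and the same fluorosulfonyl-bearing end, and they differ in the linker that joins the two.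

Compound 4, `CC1(C)N=C(N)N=C(N)N1c1ccc(OCc2ccc(C(=O)Nc3ccc(S(=O)(=O)F)cc3)cc2)c(Cl)c1`, has not yet been measured. It differs from compound 3 in one place: 4-(fluorosulfonyl)phenyl in place of 3-(fluorosulfonyl)phenyl on an amide-type nitrogen. The two structures hold the same atoms joined differently, so the change is a rearrangement on the amide-type nitrogen rather than an addition or a loss.

For the measured compounds named here, no pair of measured compounds shows a change of this kind, so the size of the step cannot be read from the numbers already in hand. The step is expected to stay within the scatter: in this assay the estimated step is a number 0.01 log units lower from compound 3 to compound 4 (within the scatter), neither clearly up nor clearly down. Compound 4 is therefore expected to give about 7.4 in this assay, with a plausible range from 6.9 to 7.9.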

Compound 4, logarithm of the reciprocal of the active concentration, log(1/C): 6.92
Compound 4: the middle estimate sits 0.48 log units above what was measured, within the range that was stated.
By their numbers in this assay, from the lowest: compounds 4 and 2 (each within the scatter of the next); then compound 3; then compound 1.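

In this assay, 4-(fluorosulfonyl)phenyl in place of 3-(fluorosulfonyl)phenyl on the amide-type nitrogen gives a number 0.49 log units lower from compound 3 to compound 4 (beyond the scatter). For the compounds shown here, this is the first pair in the set that differs in only one place, and its two compounds hold the same atoms, so a rearrangement alone, with nothing added or lost, is enough to move the number beyond the usual scatter. Nothing at hand tells why this rearrangement has this result.

Going by these compounds, whether the same rearrangement would also lower the number with the linker of compound 1 stays open, since this single pair shows it on one linker only. Also open, on these data alone, is how a carboxylic acid or an amine would fare in place of the fluorosulfonyl group on that ring.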